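Amide-nitrogen ring swap: from compound 3 to compound 4

The compounds below may be only part of what the source reports. "The series", "measured", "known", "first", "only" and "open" are said of these compounds alone.

Three amides on one shared core have numbers in a functional assay on the whole organism (strain Wistar) for inhibition, with Rattus norvegicus as the target, read by paw edema, at a dose of 100 mg/kg by the oral route; on this read-out higher numbers stand for more inhibition at the one dose given (going by the name of the read-out) and lower numbers for less inhibition. Compound 1 `COc1cc2c(cc1OC)C(CC(=O)Nc1cccc(Cl)c1)CC2` gives 25.8%; compound 2 `COc1cc2c(cc1OC)C(CC(=O)Nc1ccc(Cl)cc1)CC2` gives 8.08%; compound 3 `COc1cc2c(cc1OC)C(CC(=O)Nc1cccc(C)c1)CC2` gives 19.2%. Compound 3 holds the second highest of the three numbers: its nearest neighbour is compound 1, the gap a number 6.6 percentage points lower from compound 1 to compound 3 (within the scatter) lying within the scatter, and its furthest is compound 2, the gap a number 11.1 percentage points higher from compound 2 to compound 3 (beyond the scatter) lying beyond it. The largest single step in the set is a number 17.7 percentage points lower from compound 1 to compound 2 (beyond the scatter).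

Compound 4 `COc1cc2c(cc1OC)C(CC(=O)Nc1ccncc1)CC2` is not yet measured. Against compound 3 the change is pyridin-4-yl in place of 3-methylphenyl on an amide-type nitrogen. Within the data shown here, no measured step replaces a ring carbon by a ring nitrogen; all three measured steps move or exchange a substituent on a ring of carbon only. Only a number 11.1 percentage points higher from compound 2 to compound 3 (beyond the scatter) changes the whole group on the amide nitrogen, and that step is modest. Among the measured compounds shown here, the present change therefore has no direct precedent, and an expectation can rest only on the spread of the three numbers. Compound 4 is expected to land near the middle of that spread, at 15% with a range from 4% to 27%. The expected step is a number 4.2 percentage points lower from compound 3 to compound 4 (within the scatter), which lies within the scatter.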

Compound 4, a percentage reported as inhibition, in the whole organism at one dose (the size of the read-out at that dose, not a potency): 11.1%
Compound 4: the middle estimate sits 3.9 percentage points above what was measured; the measured number falls inside the stated range.
By their numbers in this assay, from the lowest: compounds 2, 4, 3 and 1 (each within the scatter of the next, the first and the last beyond it).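

In this assay, the first ring with a hetero atom on the amide-type nitrogen gives a number 8.1 percentage points lower from compound 3 to compound 4 (within the scatter) and a number 3 percentage points higher from compound 2 to compound 4 (within the scatter), so pyridin-4-yl cannot be told apart from either 3-methylphenyl or 4-chlorophenyl at this position. Only the comparison with 3-chlorophenyl separates, with a number 14.7 percentage points lower from compound 1 to compound 4 (beyond the scatter), and this modest step leaves compound 1 as the one amide here that stands clear of compound 4 as well as of compound 2. No available evidence bears on why the ring nitrogen leaves the number where it is.

Still open, going by these compounds, is how much of the step from the 3-methylphenyl amide belongs to the ring nitrogen and how much to the loss of the methyl, since the change makes both at once and a plain phenyl group on the amide nitrogen would separate the two. Also open, on these data alone, is whether pyridin-3-yl, with its ring nitrogen placed differently, would stay with compound 4 or come closer to compound 1.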